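Series notes: amine change at the shared core

A few compounds are considered here, and "the series" means these few. Any claim that something is new, unique, unknown or untested is made for them only; others in the source may bear on it.

Compound 1 `CCN(c1nc(Cl)nc(N[C@@H](C)c2ccccc2)n1)C(C)C` carries the lowest number of the three measured compounds in an ADME assay on the whole organism for inhibition, with Oryza sativa as the target, with a stated time of 4 days; a higher number here means a weaker inhibitor, a lower number a stronger inhibitor. Compound 1 gives 537 nM. Its enantiomer, compound 2 `CCN(c1nc(Cl)nc(N[C@H](C)c2ccccc2)n1)C(C)C`, gives 3550 nM, a step of a 6.6-fold higher number from compound 1 to compound 2 (0.82 log units; beyond the scatter), which is tied to the fact that compounds 1 and 2 differ only in the configuration as drawn. Compound 3 `CNc1nc(Cl)nc(N[C@H](C)c2ccccc2)n1`, with methylamino in place of ethyl(isopropyl)amino on the aromatic carbon, gives 22400 nM, a step of a 6.3-fold higher number from compound 2 to compound 3 (0.80 log units; beyond the scatter).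

The not yet measured compound 4 `CCC(CC)Nc1nc(Cl)nc(N[C@@H](C)c2ccccc2)n1` differs from compound 1 by (pentan-3-yl)amino in place of ethyl(isopropyl)amino on an aromatic carbon. The step from compound 2 to compound 3 is the one that bears on this change, as it alters the same amino group on the same aromatic carbon, and it was modest in size and toward a weaker inhibitor. Compound 4 keeps the configuration of compound 1 and a group of the same size, so only a modest shift is expected, more likely toward a higher number than a lower one, and the estimated step is a 1.7-fold higher number from compound 1 to compound 4 (0.22 log units; within the scatter). Compound 4 is expected to give about 900 nM, within a range of 250 nM to 3000 nM in this assay.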

Compound 4, half-maximal inhibitory concentration: 35500 nM
Beside the measured number, compound 4's estimate is 39-fold (1.60 log units) below it; measured number outside the range, above it.
By their numbers in this assay, from the lowest: compound 1; then compound 2; then compounds 3 and 4 (each within the scatter of the next).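

Replacing ethyl(isopropyl)amino with (pentan-3-yl)amino, at the same place on the shared core, gives a large step in this assay: a 66-fold higher number from compound 1 to compound 4 (1.82 log units; beyond the scatter). The earlier amine step, a 6.3-fold higher number from compound 2 to compound 3 (0.80 log units; beyond the scatter), replaced the group with the smaller methylamino, whereas this one keeps the heavy-atom count and the configuration, so this position responds to how the same atoms are joined and not only to how many there are. The entering group carries a hydrogen-bond donor and the leaving group none, but nothing measured here bears on the cause of this step.

The compounds shown cannot separate the added donor from the changed branching, a question that ethyl(pentan-3-yl)amino or diethylamino at this position would address. Also open, going by these compounds, is whether the difference between the two configurations persists with (pentan-3-yl)amino in place.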